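The compounds below may be only part of what the source reports. "The series", "measured", "known", "first", "only" and "open" are said of these compounds alone.

Among the compounds with values here, compound 2 `COc1cc(-c2nnc3n2NC(c2cccs2)C(C(=O)c2ccc(F)cc2)S3)cc(OC)c1OC` stands at the top of the two numbers measured so far: in a functional assay on PC-3 cells (Homo sapiens) for cytotoxicity, read by MTT assay, with a stated time of 48 h (on this read-out higher numbers stand for weaker inhibition and lower numbers for stronger inhibition), compound 2 gives 27400 nM, whereas compound 1 `COc1cc(-c2nnc3n2NC(c2cccs2)C(C(=O)c2ccc(C)cc2)S3)cc(OC)c1OC` gives 5090 nM. Within the data shown here, these two differ only by fluoro in place of methyl on an aromatic carbon, and that step, a 5.4-fold higher number from compound 1 to compound 2 (0.73 log units; beyond the scatter), is the sole measured step in the set. Compound 3 `COc1cc(-c2nnc3n2NC(c2cccs2)C(C(=O)c2ccc(Cl)cc2)S3)cc(OC)c1OC` is reached by a further change at the same place: chloro in place of fluoro on an aromatic carbon. Among the measured compounds shown here, no measured step puts a chloro on this ring, so the lone step bears on the question only indirectly, showing that the group at this position can move the read-out by a modest amount. A shift back toward the value of compound 1 is expected, but smaller than the measured step. For compound 3 the expected step is a 2.3-fold lower number from compound 2 to compound 3 (0.36 log units; beyond the scatter), giving an estimate of 12000 nM with a range from 4000 nM to 35000 nM in this assay.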

Compound 3, half-maximal inhibitory concentration: 32500 nM
For compound 3 the middle estimate is 2.7-fold (0.43 log units) below the measured one; measured number inside the range.
By their numbers in this assay, from the lowest: compound 1; then compounds 2 and 3 (each within the scatter of the next).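

In this assay, chloro in place of fluoro on this aromatic carbon gives a 1.2-fold higher number from compound 2 to compound 3 (0.07 log units; within the scatter) and so does not separate the two halogens. Chloro in place of methyl gives a 6.4-fold higher number from compound 1 to compound 3 (0.81 log units; beyond the scatter) and, like the earlier fluoro step, lies beyond the scatter, so among these three compounds the methyl compound, compound 1, is the most potent and neither halogen comes close to it. No supporting measurement here explains why methyl stands apart from the two halogens.

As far as these compounds go, it remains open whether methyl itself matters or whether other groups at this position, such as an ethyl chain, an amine or a carboxylic acid, would give similar or lower numbers. These three compounds also cannot show whether the same order holds in other cell types.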